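Changing the end group of compound 3

The source may hold more compounds than are shown below. What is called first, only, known or untested is meant among the compounds shown, and "the series" means these compounds.

Measured in a physicochemical assay for solubility, read by chemiluminescence, in phosphate buffer, measured as kinetic solubility, at pH 7.4; a lower number here means a less soluble compound, a higher number a more soluble compound:
Compound 1 `O=C(NCC1(c2nc(-c3ccccc3)cs2)CCOCC1)c1ccc(-c2cnco2)cc1`: 71000 nM
Compound 2 `O=C(NCC1(c2nc(-c3ccccc3)cs2)CCOCC1)c1ccc(CN2CCCCC2)cc1`: >= 396000 nM, a limit of the assay and not a number
Compound 3 `Cn1c(Nc2ccc(C(=O)NCC3(c4nc(-c5ccccc5)cs4)CCOCC3)cc2)nc2ccccc21`: 10000 nM

Compound 3 stands lowest of the three, and compound 1 is its nearest neighbour, with a 7.1-fold lower number from compound 1 to compound 3 (0.85 log units; beyond the scatter). The comparison with compound 2 rests on a limit and gives an at least 39-fold lower number from compound 2 to compound 3 (1.59 log units; beyond the scatter).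

Compound 4 `O=C(NCC1(c2nc(-c3ccccc3)cs2)CCOCC1)c1ccc(Nc2ccccn2)cc1` keeps the shared core of compound 3 and changes one group: pyridin-2-yl in place of 1-methyl-1H-benzimidazol-2-yl on a nitrogen on an aromatic ring. Cut one bond further out, this reads (1-methyl-1H-benzimidazol-2-yl)amino to (pyridin-2-yl)amino.

For the measured compounds named here, no measured step makes this exact exchange. The two steps just given bear on it only indirectly: in both, the (1-methyl-1H-benzimidazol-2-yl)amino group enters on an aromatic carbon and the number falls, modestly from compound 1 and by a large amount from compound 2. Compound 4 keeps the amino link but loses the 1-methyl-1H-benzimidazol-2-yl part, so a modest rise is expected, smaller than the fall in a 7.1-fold lower number from compound 1 to compound 3 (0.85 log units; beyond the scatter). Going by the values given here, no measured compound carries pyridin-2-yl, so this expectation is loose.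

In this assay the estimated step is a 2.5-fold higher number from compound 3 to compound 4 (0.40 log units; beyond the scatter). For compound 4 the expected value is 25000 nM, with an estimated range from 7000 nM to 90000 nM.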

Compound 4, solubility: 12000 nM
Compound 4: middle estimate off by 2.1-fold (0.32 log units), on the high side; the range from low to high includes it.
By their numbers in this assay, from the lowest: compounds 3 and 4 (each within the scatter of the next); then compound 1. At a limit, above all of these: compound 2.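

In this assay, the exchange on the nitrogen gives a 1.2-fold higher number from compound 3 to compound 4 (0.08 log units; within the scatter), so replacing the two-ring 1-methyl-1H-benzimidazol-2-yl with the single-ring pyridin-2-yl leaves no difference that can be read. For the compounds shown here, the earlier compounds tied the low number to only one group on this link, whereas compound 4 shows that a second group on the same amino link also stands clearly under the oxazole compound, with a 5.9-fold lower number from compound 1 to compound 4 (0.77 log units; beyond the scatter). The gap to the piperidine compound is large, at an at least 33-fold lower number from compound 2 to compound 4 (1.51 log units; beyond the scatter), but that step starts from a limit of the assay and not a number: the limit of >= 396000 nM in this assay, at which 1 of the 4 values shown sits.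

As far as these compounds go, what stays open is whether the ring on the nitrogen matters at all, or whether the amino link alone goes with these lower numbers, and a plain amine or a short alkyl chain such as ethyl on that nitrogen would bear on this. It is also open whether a piperidine or a carboxylic acid attached to the pyridin-2-yl ring would lift the number towards that of compound 2, since the compounds shown carry neither group on that ring.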